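Alkyl-to-amino swap at the ring position next to nitrogen

The source may report more compounds than this note shows. Statements on the series, on what has been measured and on what is new or still open speak of the compounds shown alone.

Compound 1 `CCCOc1ccc(C(=O)Nc2cccc(C)n2)cc1` gives 7500 nM in an in vitro assay on HEK-tsA201 cells for antagonist activity at Neuronal acetylcholine receptor; alpha4/beta2 (Homo sapiens), read by fluorescence and calcium flux; on this read-out higher numbers stand for weaker inhibition and lower numbers for stronger inhibition. Compound 2 `CCCOc1ccc(C(=O)Nc2cccc(CC)n2)cc1` gives 37600 nM and stands as the higher of the two numbers; the step of a 5.0-fold higher number from compound 1 to compound 2 (0.70 log units; beyond the scatter) separates it from compound 1. Compound 3 `CCCNc1cccc(NC(=O)c2ccc(OCCC)cc2)n1` differs by propylamino in place of ethyl on an aromatic carbon. Among the measured compounds shown here, the single measured step, from compound 1 to compound 2, altered a saturated chain and does not match this change; no measured step bears on it directly. The expected step for compound 3 is a 1.1-fold higher number from compound 2 to compound 3 (0.03 log units; within the scatter), with wide uncertainty. The estimate for compound 3 is 40000 nM, range 10000 nM to 160000 nM.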

Compound 3, half-maximal inhibitory concentration: 15400 nM
Estimate against measurement, compound 3: 2.6-fold (0.41 log units) above; the range from low to high includes it.
By their numbers in this assay, from the lowest: compound 1; then compound 3; then compound 2.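

Propylamino at this position gives a 2.4-fold lower number from compound 2 to compound 3 (0.39 log units; beyond the scatter), so the rise seen with ethyl does not simply continue with a larger group. Against methyl it gives a 2.1-fold higher number from compound 1 to compound 3 (0.31 log units; beyond the scatter), which leaves compound 1 with the lowest number of the three. No supporting data bear on why the order runs this way.

Propylamino changes both the atom bound to the ring and the chain length, and the compounds shown do not separate the two. A plain propyl chain and a methylamino group would pull these apart.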